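A few compounds are considered here, and "the series" means these few. Any claim that something is new, unique, unknown or untested is made for them only; others in the source may bear on it.

Three compounds have been measured in an assay on mitochondria from L6 cells (Rattus norvegicus) for activation, with a stated time of 90 min; on this read-out lower numbers stand for an effect already at smaller amounts and higher numbers for an effect only at larger amounts of compound:
compound 1, `Oc1nc2nonc2nc1Nc1ccc(OCC(F)(F)F)cc1`, gives 42300 nM;
compound 2, `Oc1nc2nonc2nc1Nc1ccc(OCC(F)(F)F)c(C(F)(F)F)c1`, gives 4000 nM;
compound 3, `Oc1nc2nonc2nc1Nc1ccccc1`, gives 66700 nM.

Compound 1 and compound 3 share a core and differ by hydrogen in place of 2,2,2-trifluoroethoxy on an aromatic carbon; on this assay their numbers lie close together, a 1.6-fold higher number from compound 1 to compound 3 (0.20 log units; within the scatter). The step from compound 1 to compound 2 is trifluoromethyl in place of hydrogen on an aromatic carbon, and it is a large one: an 11-fold lower number from compound 1 to compound 2 (1.02 log units; beyond the scatter).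

Compound 4, `Oc1nc2nonc2nc1Nc1ccccc1C(F)(F)F`, has not yet been measured. It differs from compound 3 by trifluoromethyl in place of hydrogen on an aromatic carbon. This is the same kind of change as the one from compound 1 to compound 2, and it occurs twice among these compounds, but the surroundings of the place are not the same: in compound 2 the entering group sits ortho to a 2,2,2-trifluoroethoxy group and meta to a large group, whereas in compound 4 it sits ortho to a large group. Within the data shown here, only the one measured pair is available as a guide, and that pair carries the change in a different setting.

Against this background the step from compound 3 to compound 4 is expected to be smaller than the one seen before, estimated at a 3.3-fold lower number from compound 3 to compound 4 (0.52 log units; beyond the scatter), resting on the fact that the earlier pair gave an 11-fold lower number from compound 1 to compound 2 (1.02 log units; beyond the scatter) while the new pair places the group differently. Compound 4 is therefore estimated to give 20000 nM, with a likely range from 5000 nM to 60000 nM.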

Compound 4, half-maximal effective concentration: 10600 nM
Compound 4: the middle estimate sits 1.9-fold (0.28 log units) above what was measured; low and high end bracket the measured number.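

In this assay, trifluoromethyl in place of hydrogen on an aromatic carbon again goes with a lower number, here a 6.3-fold lower number from compound 3 to compound 4 (0.80 log units; beyond the scatter). Set beside the earlier pair, the step keeps its direction, and its size does not differ measurably between the two cores: the same change on two cores in this assay, an 11-fold lower number (1.02 log units; beyond the scatter) from compound 1 to compound 2 and a 6.3-fold lower number (0.80 log units; beyond the scatter) from compound 3 to compound 4, 1.7-fold (0.23 log units) apart, within the scatter of two such steps This shows that, in these two pairs, the change carried over from one core to the other, but two pairs make no rule for the series, and since the group enters ortho to a large group only in compound 4, they cannot separate the effect of the core from that of the place on the ring.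

The compounds shown leave open whether the same step would hold at other places on the aromatic ring, or on a core carrying a different substituent there, such as a longer chain or an amine. They also leave open whether another group in place of the hydrogen, such as a nitrile, a chlorine atom or a carboxylic acid, would give a step of similar size and direction.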